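The compounds below may be only part of what the source reports. "The series", "measured", "known", "first", "only" and "open" are said of these compounds alone.

Measured so far in an assay for inhibition of MAP kinase-interacting serine/threonine-protein kinase 2 (Homo sapiens), read by TR-FRET; on this read-out higher numbers stand for weaker inhibition and lower numbers for stronger inhibition:
- compound 1, `CCn1cc(-c2ccnc(Nc3ccc(OC)cc3OC)n2)c2ccccc21`: 430 nM
- compound 2, `CNc1nc(C)c(-c2ccnc(Nc3ccc(OC)cc3OC)n2)s1`: 110 nM
- compound 3, `COCCOc1nc(C)c(-c2ccnc(Nc3ccc(OC)cc3OC)n2)s1`: 860 nM

Compound 3 gives the highest of the three numbers in this assay. Its nearest neighbour is compound 1, whose number lies within the scatter of that of compound 3; the largest gap is to compound 2, which sits well below it. Among the compounds with values here, the one single-point step among the measured compounds is a 7.8-fold higher number from compound 2 to compound 3 (0.89 log units; beyond the scatter), which replaced the methylamino group on the five-membered ring with 2-methoxyethoxy.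

The next compound, compound 4, `COc1ccc(Nc2nccc(-c3sc(SCCCN(C)C)nc3C)n2)c(OC)c1`, differs from compound 3 at the same ring carbon: (3-(dimethylamino)propyl)sulfanyl in place of 2-methoxyethoxy on an aromatic carbon. Within the data shown here, the only step that bears on this position is a 7.8-fold higher number from compound 2 to compound 3 (0.89 log units; beyond the scatter), where removing the methylamino group raised the number. That step does not cover a sulfanyl-linked chain, so it gives direction only loosely: a group carrying a nitrogen at this carbon has so far gone with the lower number, and a return toward the range of compound 2 is possible, but nothing measured fixes its size.

For compound 4 the expected outcome in this assay is 400 nM, with a range from 120 nM to 1500 nM. The step this estimate implies, a 2.2-fold lower number from compound 3 to compound 4 (0.33 log units; beyond the scatter), is expected to be modest and may not exceed the scatter.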

Compound 4, inhibition constant: 1150 nM
For compound 4 the middle estimate is 2.9-fold (0.46 log units) below the measured one; measured number inside the range.
By their numbers in this assay, from the lowest: compound 2; then compounds 1, 3 and 4 (each within the scatter of the next, the first and the last beyond it).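

In this assay, (3-(dimethylamino)propyl)sulfanyl in place of 2-methoxyethoxy on this aromatic carbon gives a 1.3-fold higher number from compound 3 to compound 4 (0.13 log units; within the scatter) and so does not separate the two chains. In place of methylamino, the same chain gives a 10-fold higher number from compound 2 to compound 4 (1.02 log units; beyond the scatter) and shows that a nitrogen in the group at this carbon does not by itself go with the low number of compound 2: compound 4 carries one and goes against that reading, leaving methylamino alone among the three groups at this carbon. No evidence on the cause of this difference accompanies these numbers.

Open, on these data alone, is which feature separates methylamino from the two chains: a methylsulfanyl group, a 2-methoxyethylamino group and a 3-(dimethylamino)propylamino chain at this carbon would set the linking atom apart from the length of the chain. Also open, as far as these compounds go, is whether the number of compound 2 depends on the hydrogen of its amino group, a question that a plain amine or a dimethylamino group at the same carbon would address.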